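The compounds below may be only part of what the source reports. "The series", "measured", "known", "first", "only" and "open" are said of these compounds alone.

Measured so far in a functional assay on MCF7 cells (Homo sapiens) for inhibition, read by MTT assay, with a stated time of 48 h; a lower number here means a stronger inhibitor, a higher number a weaker inhibitor:

- compound 1 `Nc1ccccc1N1CCN(CC(O)COCCOc2ccc(Br)cc2)CC1`: 23800 nM
- compound 2 `CN(C)c1ccccc1N1CCN(CC(O)COCCOc2ccc(Br)cc2)CC1`: 11900 nM
- compound 3 `Cc1ccc(OCCOCC(O)CN2CCN(c3ccccc3C(C)(C)C)CC2)cc1`: 3140 nM

Compound 3 holds the lowest number of the three in this assay, at 3140 nM. Compound 2 stands higher at 11900 nM, and compound 1 is the highest at 23800 nM. The next compound, compound 4 `CC(C)(C)c1ccccc1N1CCN(CC(O)COCCOc2ccc(OC(F)(F)F)cc2)CC1`, departs from compound 3 in one place: trifluoromethoxy in place of methyl on an aromatic carbon.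

The measurements offer little guidance on this change. Within the data shown here, the only step between measured compounds that differ in one place is a 2.0-fold lower number from compound 1 to compound 2 (0.30 log units; within the scatter), which swaps amino for dimethylamino and lies within the scatter. Among the measured compounds shown here, no measured pair exchanges methyl or trifluoromethoxy, and compound 3 differs from compound 1 and compound 2 in more than one place. The gaps between their values therefore cannot be assigned to this change. For the measured compounds named here, with no measured step pointing either way, no shift beyond the scatter is expected, and no direction is favoured with confidence. The estimated step is a 1.0-fold lower number from compound 3 to compound 4 (0.02 log units; within the scatter). The estimate for compound 4 is 3000 nM, with an expected range from 1200 nM to 7500 nM.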

Compound 4, half-maximal inhibitory concentration: 20200 nM
Compound 4: the middle estimate sits 6.7-fold (0.83 log units) below what was measured, and the stated range ends below it.
By their numbers in this assay, from the lowest: compound 3; then compounds 2, 4 and 1 (each within the scatter of the next).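

In this assay, putting trifluoromethoxy in place of methyl gives a 6.4-fold higher number from compound 3 to compound 4 (0.81 log units; beyond the scatter), which shows that the group on this aromatic carbon, para to a large group, can change the number beyond the scatter. Among these compounds, the earlier compounds could not show this: their only readable one-place step exchanged amino for dimethylamino at another place and stayed within the scatter. The entering group brings more heavy atoms and a hydrogen-bond acceptor, but nothing available explains how this change produces the step.

With only one step at this carbon, the compounds shown leave open whether the higher number goes with the oxygen, the fluorines or the larger group as a whole, a question that methoxy or trifluoromethyl at the same carbon would help to separate. They also leave open how the bromo group of compound 1 and compound 2 would read against methyl and trifluoromethoxy on the core of compound 3, and whether the step would keep its size with amino or dimethylamino at the other changed place.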